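Phenoxy in place of benzyloxycarbonyl: a first estimate

This account rests on a few compounds, and the source may have more. Where it says the series, first, only, none or still open, it means among the compounds named here.

Of the compounds shown here, two have numbers so far. In a functional assay on HeLa cells (Homo sapiens) for inhibition, read by CellTiter-Glo, with a stated time of 48 h, in the presence of a further agent that is not named here (on this read-out lower numbers stand for stronger inhibition of growth and higher numbers for weaker inhibition of growth), compound 1 `C#CCCCC(=O)Nc1ccc(C(=O)c2ccc(Nc3ncc(F)c(Nc4ccccc4NS(C)(=O)=O)n3)cc2)cc1` gives 5700 nM, and compound 2 `CS(=O)(=O)Nc1ccccc1Nc1nc(Nc2ccc(C(=O)OCc3ccccc3)cc2)ncc1F` gives 61900 nM. Compound 2 therefore holds the higher of the two numbers, and its gap to compound 1 lies beyond the scatter.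

Compound 3 `CS(=O)(=O)Nc1ccccc1Nc1nc(Nc2ccc(Oc3ccccc3)cc2)ncc1F` keeps the shared core of compound 2 and carries phenoxy in place of benzyloxycarbonyl on an aromatic carbon, para to a large group: phenoxy in place of benzyloxycarbonyl on an aromatic carbon. Within the data shown here, no measured pair shows this change, so the expectation is a judgement with wide margins. A modest move towards a lower number in this assay is expected, as compound 2 at 61900 nM already stands high. The expected change is a 2.5-fold lower number from compound 2 to compound 3 (0.39 log units; beyond the scatter), though a result within the scatter would not surprise. For compound 3 the estimated value is 25000 nM, with an expected range of 7000 nM to 80000 nM.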

Compound 3, concentration for 50% growth inhibition: 14000 nM
Compound 3: middle estimate off by 1.8-fold (0.25 log units), on the high side; the measured number falls inside the stated range.
By their numbers in this assay, from the lowest: compound 1; then compound 3; then compound 2.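

At this aromatic carbon, para to a large group, the number responds to the group carried: phenoxy in place of benzyloxycarbonyl gives a 4.4-fold lower number from compound 2 to compound 3 (0.65 log units; beyond the scatter) in this assay. The entering group keeps the six-membered aromatic ring of carbon only, while the heavy atoms fall in number, the hydrogen-bond acceptors fall from 2 to 1, and the double bond outside aromatic rings is lost, so this single step cannot separate these differences from one another. No measurement available on the series accounts for the step.

Still open, from the compounds shown here alone, is whether the aromatic ring is needed at this position, which a primary amine or a carboxylic acid on the same carbon would test. Also open, going by these compounds, is whether a longer chain between the oxygen and the ring would lower or raise the number.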